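Chloro to Trifluoromethyl on a Weak Cell-Growth Inhibitor

This account rests on a few compounds, and the source may have more. Where it says the series, first, only, none or still open, it means among the compounds named here.

Three close relatives share one core and differ only in the group on a six-membered carbon ring. Compound 1 `C=CCCCCOc1ncc(-c2ccccc2OC)n1C` carries hydrogen there, compound 2 `C=CCCCCOc1ncc(-c2cc(C(C)C)ccc2OC)n1C` isopropyl, and compound 3 `C=CCCCCOc1ncc(-c2cc(Cl)ccc2OC)n1C` chloro. In a functional assay on LoVo cells (Homo sapiens) for inhibition, read by colorimetric assay and MTT assay, with a stated time of 72 h (a higher number here means a weaker inhibitor, a lower number a stronger inhibitor), compound 1 gives 4000 nM, compound 2 gives 3000 nM, and compound 3 gives 28000 nM. Compound 3 therefore stands as the weakest of the three: its number is the highest, and both of its steps to the others lie beyond the scatter, with a 7.0-fold higher number from compound 1 to compound 3 (0.85 log units; beyond the scatter) and a 9.3-fold higher number from compound 2 to compound 3 (0.97 log units; beyond the scatter). Between compound 1 and compound 2 the change is small, a 1.3-fold lower number from compound 1 to compound 2 (0.12 log units; within the scatter).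

Compound 4 `C=CCCCCOc1ncc(-c2cc(C(F)(F)F)ccc2OC)n1C` is not yet measured. It differs from compound 3 in one place: trifluoromethyl in place of chloro on an aromatic carbon. The two steps that bear on this change are the ones leading into compound 3, since both show that chloro at this position goes with a clearly higher number than either hydrogen or isopropyl. Replacing chloro with something else is thus expected to lower the number, though no direct measurement of trifluoromethyl exists here. The expected step from compound 3 to compound 4 in this assay is a 3.5-fold lower number from compound 3 to compound 4 (0.54 log units; beyond the scatter). Compound 4 is estimated at 8000 nM, within a range of 2500 nM to 25000 nM.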

Compound 4, half-maximal inhibitory concentration: 51000 nM
The estimate for compound 4 lay 6.4-fold (0.80 log units) below the measured number, outside the stated range (above it).
By their numbers in this assay, from the lowest: compounds 2 and 1 (each within the scatter of the next); then compounds 3 and 4 (each within the scatter of the next).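

In this assay, trifluoromethyl and chloro at this position on the carbon ring cannot be told apart, with a 1.8-fold higher number from compound 3 to compound 4 (0.26 log units; within the scatter), even though chloro brings one heavy atom and trifluoromethyl brings four. Both groups stand clearly apart from the two that came before, as trifluoromethyl gives a 13-fold higher number from compound 1 to compound 4 (1.11 log units; beyond the scatter) when it replaces hydrogen and a 17-fold higher number from compound 2 to compound 4 (1.23 log units; beyond the scatter) when it replaces isopropyl, so among these four compounds the numbers fall into two pairs, hydrogen with isopropyl and chloro with trifluoromethyl, and no compound goes against that split. Nothing available here offers an explanation for why the groups pair up this way.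

As far as these compounds go, it remains open whether an amine, a carboxylic acid or a simple methyl at this position would join the hydrogen and isopropyl pair, the chloro and trifluoromethyl pair, or neither. Also open, from the compounds shown here alone, is whether the same two pairs would appear with a shorter chain in place of the long one on the shared core, or with a methoxy group swapped for a hydroxyl.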